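A Sulfonamide Methyl Group Moves, the Read-Out Watched

A few compounds are considered here, and "the series" means these few. Any claim that something is new, unique, unknown or untested is made for them only; others in the source may bear on it.

Compound 1, `Cc1ccc(S(=O)(=O)Nc2ccc(-c3nc4ccccc4o3)cc2)cc1`, was tested in an assay on isolated protein for inhibition of malate dehydrogenase, mitochondrial (Sus scrofa), with stated times of 45 min and 30 min; on this read-out higher numbers stand for weaker inhibition and lower numbers for stronger inhibition. In this assay compound 1 returns only a limit, > 63000 nM, and not a number. Two compounds with the same core were run alongside it. Compound 2, `O=S(=O)(Nc1ccc(-c2nc3ccccc3o2)cc1)c1ccc(F)c(C(F)(F)F)c1`, gives only a limit in this assay, > 63000 nM. Compound 3, `O=[N+]([O-])c1cc(S(=O)(=O)Nc2ccc(-c3nc4ccccc4o3)cc2)ccc1Cl`, also gives only a limit in this assay, > 63000 nM. Every value shown thus rests at the limit of > 63000 nM in this assay, at which 3 of the 3 values shown sit, so compound 1 cannot be ranked against its companions; all that is known is that it stands at the limit with them.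

Compound 4, `Cc1ccccc1S(=O)(=O)Nc1ccc(-c2nc3ccccc3o2)cc1`, has the same atoms as compound 1, joined differently: 2-methylphenyl in place of 4-methylphenyl on a sulfonyl sulfur. Among the compounds with values here, no step between two measured compounds exists here to guide the reading of this change. The account therefore expects the step that the limit leaves unreadable from compound 1 to compound 4 to be none beyond the scatter, and most likely the assay again reports only a limit. Compound 4 is estimated to give 100000 nM in this assay, with a range from 30000 nM to 400000 nM.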

Compound 4, half-maximal inhibitory concentration: > 63000 nM
Compound 4 was reported as a limit; the forecaster's own chance of this, stated with the estimate: 85%; the middle value does not contradict the limit.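

Compound 1 and compound 4 both return a limit and not a number in this assay, so moving the methyl group yields no readable step: the limit of > 63000 nM in this assay, at which 4 of the 4 values shown sit.

The compounds shown leave open how they would rank in this assay, and whether any group on the sulfonyl sulfur gives a value short of the limit.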